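Urea to Benzamide on a Trimethoxyphenyl Scaffold

The compounds below may be only part of what the source reports. "The series", "measured", "known", "first", "only" and "open" are said of these compounds alone.

Compound 1 `COc1cc(NC(=O)Nc2ccccc2)cc(OC)c1OC` carries a urea linking the shared core to an anilino group. In a functional assay on ONS-76 cells (Homo sapiens) for cytotoxicity, read by MTT assay, with a stated time of 72 h (on this read-out lower numbers stand for stronger inhibition and higher numbers for weaker inhibition), compound 1 is recorded as "not determined" (no result reported), so no single number places it on the scale. Going by the values given here, a related urea, compound 2 `COc1ccc(NC(=O)Nc2cc(OC)c(OC)c(OC)c2)cc1`, is the only compound with a result: in this assay compound 2 gives 12900 nM, a weak value that sets the only reference point here. Compound 3 `COc1cc(NC(=O)c2ccc(F)cc2)cc(OC)c1OC` replaces the urea of compound 1 with a benzamide; the change is 4-fluorophenyl in place of anilino on a carbonyl carbon. Among the compounds with values here, with no measured pair in this assay that shares this change, no direction can be read from the data, and a step not beyond the usual scatter is as plausible as any other. Taking the weak result of compound 2 in this assay as the nearest anchor, compound 3 is expected to give about 20000 nM, with a range from 5000 nM to 80000 nM.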

Compound 3, half-maximal inhibitory concentration: >= 125000 nM
Compound 3: no number, only a limit; the forecaster's own chance of this, stated with the estimate: 30%; middle value at least 6.2-fold (0.79 log units) away from the limit.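

No step can be read from compound 1 to compound 3: compound 1 has no single number, and the result for compound 3 is a limit, not a number. The compounds shown leave open how far the 4-fluorophenyl benzamide and the anilino urea differ on this read-out.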